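Nitro to Chloro on the Aryl Ring: What to Expect

A few compounds are considered here, and "the series" means these few. Any claim that something is new, unique, unknown or untested is made for them only; others in the source may bear on it.

In a functional assay on NCI-H460 cells (Homo sapiens) for cytotoxicity, read by sulforhodamine B assay (on this read-out higher numbers stand for lower toxicity in this test and lower numbers for higher toxicity in this test), three close relatives have been tested, and each stopped at a limit rather than giving a number. Compound 1 `CC1=CC[C@@H]([C@@](C)(O)CCCC(C)(C)NC(=S)N/N=C\c2ccccc2)CC1` reached > 100000 nM in this assay, which is a limit. Compound 2 `COc1ccc(/C=N\NC(=S)NC(C)(C)CCC[C@](C)(O)[C@@H]2CC=C(C)CC2)cc1` likewise gave > 100000 nM in this assay, again a limit. Compound 3 `CC1=CC[C@@H]([C@@](C)(O)CCCC(C)(C)NC(=S)N/N=C\c2ccccc2[N+](=O)[O-])CC1` also gave > 100000 nM in this assay, once more a limit. Because all three sit at the limit of > 100000 nM in this assay, at which 3 of the 3 values shown sit, the computed steps a step that the two limits leave unreadable from compound 1 to compound 2, a step that the two limits leave unreadable from compound 1 to compound 3 and a step that the two limits leave unreadable from compound 2 to compound 3 cannot be read for size; compound 3 therefore stands only at a limit, with no number to place it against its neighbours. Compound 4 `CC1=CC[C@@H]([C@@](C)(O)CCCC(C)(C)NC(=S)N/N=C\c2ccccc2Cl)CC1` differs from compound 3 by chloro in place of nitro on an aromatic carbon. Among the compounds with values here, no measured step reports a readable size, so nothing points to a move beyond the scatter, and the expectation is that compound 4 stays where the others sit. Compound 4 is expected to give about 150000 nM, within 50000 nM to 500000 nM. The expected step is a step that the limit leaves unreadable from compound 3 to compound 4.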

Compound 4, concentration lethal to 50% of the cells: > 100000 nM
Compound 4: a limit, no number (the forecaster's own chance of this, stated with the estimate: 80%); the middle value lies beyond the limit too.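

Within the data shown here, compound 4 stops at a limit, as compound 1, compound 2 and compound 3 do, so no step among them can be read for size: the limit of > 100000 nM in this assay, at which 4 of the 4 values shown sit.

The compounds shown leave open whether any group on the aromatic ring gives a true number in this assay and how these groups would then compare.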